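Replacing the 5-hydroxypentyl group of compound 1

This account rests on a few compounds, and the source may have more. Where it says the series, first, only, none or still open, it means among the compounds named here.

- compound 1 `COc1cc(NC(C)CCCNC(=O)NNC(=O)NCCCCCO)c2ncccc2c1` gives 168000 nM in a functional assay on MIA PaCa-2 cells (Homo sapiens) for inhibition, read by MTT assay, with a stated time of 4 days; on this read-out higher numbers stand for weaker inhibition and lower numbers for stronger inhibition
- compound 2 `COc1cc(NC(C)CCCNC(=O)NNC(=O)NCCNC(c2ccccc2)(c2ccccc2)c2ccccc2)c2ncccc2c1` gives 5000 nM in this assay
- compound 3 `COc1cc(NC(C)CCCNC(=O)NNC(=O)N(C)C(c2ccccc2)c2ccccc2)c2ncccc2c1` gives 18000 nM in this assay

Compound 1 has the highest number of the three, which makes it the weakest inhibitor so far. Compound 3 lies closest to it and compound 2 lies furthest away.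

The next compound, compound 4 `COc1cc(NC(C)CCCNC(=O)NNC(=O)NC(CO)(CO)CO)c2ncccc2c1`, keeps the rest of compound 1 and changes one group: 2-hydroxy-1,1-bis(hydroxymethyl)ethyl in place of 5-hydroxypentyl on an amide-type nitrogen. Within the data shown here, no measured pair shows this change on its own, so any forecast is uncertain. Among the measured compounds shown here, neither group has a ring, and the only measured compound with a ringless group at this place is compound 1 (168000 nM), so that value is the natural anchor. In this assay no step beyond the scatter is expected, and the estimated step of a 1.1-fold higher number from compound 1 to compound 4 (0.03 log units; within the scatter) could still turn out larger in either direction. Compound 4 is estimated at 180000 nM with an expected range of 60000 nM to 500000 nM in this assay.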

Compound 4, half-maximal inhibitory concentration: > 250000 nM
Compound 4: only a limit was reported; the forecaster's own chance of this, stated with the estimate: 20%; at least 1.3-fold (0.14 log units) between middle value and limit.
By their numbers in this assay, from the lowest: compound 2; then compound 3; then compound 1. At a limit, above all of these: compound 4.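

Compound 4 sits at a limit of the assay and not at a number: the limit of > 250000 nM in this assay, at which 1 of the 4 values shown sits. The step can therefore be read only as a floor, an at least 1.4-fold higher number from compound 1 to compound 4 (0.17 log units; that floor lies within the scatter), and that floor does not show that this change weakens inhibition beyond the usual scatter. Still, this second ringless group on the amide-type nitrogen, 2-hydroxy-1,1-bis(hydroxymethyl)ethyl, carries more hydrogen-bond donors and acceptors than 5-hydroxypentyl and gives no sign of stronger inhibition in this assay.

The two groups differ both in their branching and in their number of hydroxyl groups, so the compounds shown cannot separate these two changes. They also leave open how a ringless group ending in an amine or a carboxylic acid, or a longer chain carrying a single terminal hydroxyl, would behave at this place.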